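Swapping Trifluoromethyl for Cyano at a Solubility Limit

A few compounds are considered here, and "the series" means these few. Any claim that something is new, unique, unknown or untested is made for them only; others in the source may bear on it.

Compound 1 is `COc1ccc(-c2cnn3c(NCc4ccccn4)cc(C)nc23)cc1`; in a physicochemical assay for solubility, read by HPLC, using the shake flask method, measured as kinetic solubility, with a stated time of 2 h, at pH 7.4 (on this read-out higher numbers stand for higher solubility and lower numbers for lower solubility), compound 1 gives < 5000 nM, which is a limit of the assay rather than a number.
Compound 2 is `Cc1cc(NCc2ccccn2)n2ncc(-c3ccc(C(F)(F)F)cc3)c2n1`; in this assay compound 2 gives < 5000 nM, again a limit and not a number.

Compound 2 therefore stands at the limit, and since compound 1 sits at the same limit, the step that the two limits leave unreadable from compound 1 to compound 2 cannot be read in either direction. Both values shown sit at this one limit (the limit of < 5000 nM in this assay, at which 2 of the 2 values shown sit).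

Compound 3 is `Cc1cc(NCc2ccccn2)n2ncc(-c3ccc(C#N)cc3)c2n1`. It differs from compound 2 by cyano in place of trifluoromethyl on an aromatic carbon. Among the compounds with values here, no measured step bears directly on this change, and the one step that exists, from compound 1 to compound 2, is unreadable, so there is no measured size to carry over.

With both known values resting at the limit, compound 3 is expected in this assay to give about 3000 nM, within a range from 500 nM to 15000 nM. The step that the limit leaves unreadable from compound 2 to compound 3 that this estimate implies is expected to stay within the usual scatter, and a reported limit rather than a number is the more likely outcome.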

Compound 3, solubility: < 5000 nM
Compound 3: no number, only a limit; the forecaster's own chance of this, stated with the estimate: 65%; the middle value lies beyond the limit too.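

Compound 3 gives a limit rather than a number in this assay, so no step can be read from compound 2 to compound 3 or from compound 1 to compound 3: the limit of < 5000 nM in this assay, at which 3 of the 3 values shown sit.

The compounds shown leave open whether compound 1, compound 2 and compound 3 truly differ in this assay, and by how much.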